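Acid in Place of Amide on a Chemokine Receptor Antagonist

The source may hold more compounds than are shown below. What is called first, only, known or untested is meant among the compounds shown, and "the series" means these compounds.

In a functional assay on cells for antagonist activity at C-C chemokine receptor type 4 (Homo sapiens), read by GTPgammaS binding (a lower number here means a stronger inhibitor, a higher number a weaker inhibitor), compound 1 `CCn1[nH]c2ncnc(NS(=O)(=O)c3cccc(Cl)c3Cl)c2c1=O` shows > 31600 nM, which is a limit of the assay and not a number. Going by the values given here, compound 2 `COc1nn(CC(N)=O)c2ncnc(NS(=O)(=O)c3cccc(Cl)c3Cl)c12` gives 501 nM in this assay, the only true number among the values shown. The other value sits at the limit (the limit of > 31600 nM in this assay, at which 1 of the 2 values shown sits). Compound 3 `COc1nn(CC(=O)O)c2ncnc(NS(=O)(=O)c3cccc(Cl)c3Cl)c12` differs from compound 2 by hydroxy in place of amino on a carbonyl carbon. Among the compounds with values here, no measured step between compounds guides this change, so a modest weakening beyond the scatter is expected: a 3.0-fold higher number from compound 2 to compound 3 (0.48 log units; beyond the scatter) in this assay. Compound 3 is estimated at 1500 nM, likely between 400 nM and 6000 nM.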

Compound 3, half-maximal inhibitory concentration: 200 nM
Estimate against measurement, compound 3: 7.5-fold (0.88 log units) above, and the stated range ends above it.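

Swapping amino for hydroxy on a carbonyl carbon gives a 2.5-fold lower number from compound 2 to compound 3 (0.40 log units; beyond the scatter) and so shows that this position tolerates carboxymethyl as well as carbamoylmethyl, with the acid the stronger inhibitor of the two. Going by these compounds alone, this is the first step that can be read at this position, since compounds 1 and 2 differ in more than one place. Nothing measured here accounts for the direction of this step.

Going by these compounds, whether a methyl ester, an amine or a longer chain ending in a carboxylic acid would do better at this position remains open. So does whether the same swap would have a similar effect on a different core.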